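A few compounds are considered here, and "the series" means these few. Any claim that something is new, unique, unknown or untested is made for them only; others in the source may bear on it.

In an assay on HL-60 cells for agonist activity at vitamin D3 receptor (Homo sapiens), read by microscopy, with a stated time of 96 h (a lower number here means that less compound is needed, a higher number that more compound is needed for the effect), the measured compounds are:
compound 1 `CCN(CC)CCNC(=O)c1ccc(C(CC)(CC)c2ccc(OCC(O)C(C)(C)C)c(C)c2)n1CC` gives 110 nM
compound 2 `C#CC(C)OC(=O)c1ccc(C(CC)(CC)c2ccc(OCC(O)C(C)(C)C)c(C)c2)n1CC` gives 200 nM

Among the compounds with values here, compound 2 has the higher of these two numbers, but its only neighbour, compound 1, lies within the scatter of it. Compound 3 `CCn1c(C(=O)Oc2ccc(CCO)cc2)ccc1C(CC)(CC)c1ccc(OCC(O)C(C)(C)C)c(C)c1` differs from compound 2 by 4-(2-hydroxyethyl)phenyl in place of 1-methylprop-2-yn-1-yl on an oxygen next to a carbonyl group. Within the data shown here, the single measured step, a 1.8-fold higher number from compound 1 to compound 2 (0.26 log units; within the scatter), also changed the group attached to the carbonyl carbon and stayed within the scatter. On that basis, a step from compound 2 to compound 3 in this assay no larger than the scatter is expected, with no clear direction. Compound 3 is therefore expected at 200 nM, between 70 nM and 600 nM, meaning an expected no change at the digits printed from compound 2 to compound 3 (within the scatter).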

Compound 3, half-maximal effective concentration: 5100 nM
Compound 3: middle estimate off by 26-fold (1.41 log units), on the low side; measured number above the stated range.
By their numbers in this assay, from the lowest: compounds 1 and 2 (each within the scatter of the next); then compound 3.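

In this assay, the group on the oxygen next to the carbonyl is not free to change: putting 4-(2-hydroxyethyl)phenyl in place of 1-methylprop-2-yn-1-yl gives a 26-fold higher number from compound 2 to compound 3 (1.41 log units; beyond the scatter) and so goes beyond the scatter, which the earlier step did not. The comparison with the (2-(diethylamino)ethyl)amino group on the carbonyl carbon, a 46-fold higher number from compound 1 to compound 3 (1.67 log units; beyond the scatter), is also beyond the scatter. Nothing at hand gives a reason for this rise.

Still open, on these data alone, is whether the aromatic ring or its 2-hydroxyethyl chain goes with the higher number. A plain phenyl on that oxygen would separate the two.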